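The source may hold more compounds than are shown below. What is called first, only, known or untested is meant among the compounds shown, and "the series" means these compounds.

Measured so far:
- Compound 1, `COc1cccc2ccc(Nc3ccccn3)nc12`: 7470 nM
- Compound 2, `COc1cccc2ccc(Nc3cc(C)ccn3)nc12`: 3820 nM
- Compound 3, `Oc1ccc(Cl)c2ccc(Nc3ccccn3)nc12`: 1290 nM

All three were tested in a functional assay on PC-3 cells (Homo sapiens) for antiproliferative activity, read by MTT assay, with a stated time of 96 h; a lower number here means a stronger inhibitor of growth, a higher number a weaker inhibitor of growth. Compound 1 and compound 2 share one core and differ only in methyl in place of hydrogen on an aromatic carbon; that change gave a 2.0-fold lower number from compound 1 to compound 2 (0.29 log units; within the scatter), so the two numbers cannot be told apart with confidence. Compound 3 has a different core; how the two cores differ is not broken down here. Among the three, compound 3 gives the lowest number in this assay, and its distance to each of the other two lies beyond the usual scatter.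

Compound 4, `Cc1ccnc(Nc2ccc3c(Cl)ccc(O)c3n2)c1`, has not yet been measured. For the measured compounds named here, it carries the core of compound 3 with methyl in place of hydrogen on an aromatic carbon, the same change as the one from compound 1 to compound 2. Because the earlier methyl gave only a 2.0-fold lower number from compound 1 to compound 2 (0.29 log units; within the scatter), a step of similar, modest size is expected here, in this assay: a 1.6-fold lower number from compound 3 to compound 4 (0.21 log units; within the scatter). The estimate for compound 4 rests on compound 3 at 1290 nM, and the expected value is 800 nM, with a likely range from 350 nM to 2000 nM.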

Compound 4, concentration for 50% growth inhibition: 10200 nM
Estimate against measurement, compound 4: 13-fold (1.11 log units) below, outside the stated range (above it).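

In this assay, methyl in place of hydrogen on the core of compound 3 gave a 7.9-fold higher number from compound 3 to compound 4 (0.90 log units; beyond the scatter), so the effect seen on the core of compound 1 did not carry over to this core, either in direction or in size: the same change on two cores in this assay, a 2.0-fold lower number (0.29 log units; within the scatter) from compound 1 to compound 2 and a 7.9-fold higher number (0.90 log units; beyond the scatter) from compound 3 to compound 4, 15-fold (1.19 log units) apart, beyond the scatter of two such steps

In this small set, then, the result of this methyl on one core is a poor guide to its result on the other. These two pairs show that the outcome depends on the core, but not which part of the core is responsible or why, and they cannot say how the methyl would behave on any third core.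

Still open, as far as these compounds go, is how an ethyl group, an amine or a carboxylic acid would behave at the same place, opposite the ring nitrogen, on either core. Also open, from the compounds shown here alone, is whether a core carrying only some of the differences between these two would follow compound 1 or compound 3.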